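A few compounds are considered here, and "the series" means these few. Any claim that something is new, unique, unknown or untested is made for them only; others in the source may bear on it.

Among the measured compounds shown here, in a physicochemical assay for solubility, measured as kinetic solubility (a higher number here means a more soluble compound, a lower number a less soluble compound), compound 1 (`C[C@H](NC(=O)c1cc(C(F)(F)F)ccc1Oc1ccccc1)c1cccc(S(C)(=O)=O)c1`) gives 57000 nM and compound 2 (`CS(=O)(=O)c1cccc(CNC(=O)c2cc(C(F)(F)F)ccc2Oc2ccccc2)c1`) gives 23000 nM as the lower of the two numbers so far. For the measured compounds named here, the only measured step is a 2.5-fold lower number from compound 1 to compound 2 (0.39 log units; beyond the scatter) and it goes with hydrogen in place of methyl on a saturated chain carbon bound to an amide-type nitrogen and an aromatic carbon. Compound 3 (`CS(=O)(=O)c1cccc([C@H](CO)NC(=O)c2cc(C(F)(F)F)ccc2Oc2ccccc2)c1`) differs from compound 2 at that same carbon, with hydroxymethyl in place of hydrogen on a saturated chain carbon bound to an amide-type nitrogen and an aromatic carbon as the change: hydroxymethyl in place of hydrogen. Read in reverse, that single modest step is the only guide, and no measured compound carries hydroxymethyl, so the guide is weak. A modest rise in this assay is therefore expected, with a 2.0-fold higher number from compound 2 to compound 3 (0.29 log units; within the scatter) as the estimated step. Compound 3 is estimated at 45000 nM within an expected range of 18000 nM to 110000 nM for now.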

Compound 3, solubility: 11000 nM
Compound 3: middle estimate off by 4.1-fold (0.61 log units), on the high side; measured number below the stated range.
By their numbers in this assay, from the lowest: compound 3; then compound 2; then compound 1.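

In this assay a substituent on the saturated chain carbon bound to an amide-type nitrogen and an aromatic carbon is not tied to one direction: methyl in compound 1 stands with the highest number of the three, hydroxymethyl in compound 3 with the lowest, and hydrogen in compound 2 between them. Hydroxymethyl in place of hydrogen goes with a 2.1-fold lower number from compound 2 to compound 3 (0.32 log units; beyond the scatter), so the drop seen on removing methyl does not reverse with this group. Hydroxy in place of hydrogen on the methyl goes with a 5.2-fold lower number from compound 1 to compound 3 (0.71 log units; beyond the scatter), and nothing at hand accounts for either shift.

From the compounds shown here alone, whether an amine or a carboxylic acid at this carbon, or a longer chain bearing the hydroxy, would sit with methyl or with hydroxymethyl stays open. Going by these compounds, the opposite configuration at this carbon also stays open.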